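The source may hold more compounds than are shown below. What is called first, only, known or untested is meant among the compounds shown, and "the series" means these compounds.

Measured in a functional assay on A-375 cells (Homo sapiens) for antiproliferative activity, read by MTT assay, with a stated time of 72 h; on this read-out higher numbers stand for weaker inhibition and lower numbers for stronger inhibition:
- compound 1 `O=C1COc2ccc(-c3cnc(Cl)c(NS(=O)(=O)c4ccc(F)cc4)c3)cc2N1C1CCCCC1`: > 40000 nM (a limit)
- compound 2 `O=C1COc2ccc(-c3cccc(NS(=O)(=O)c4ccc(F)cc4)c3)cc2N1`: 20100 nM
- compound 3 `CC(C)N1C(=O)COc2ccc(-c3cnc(Cl)c(NS(=O)(=O)c4ccc(F)cc4)c3)cc21`: 25500 nM

Within the data shown here, compound 2 and compound 3 hold the only two actual numbers, and these lie within the scatter of each other. The result for compound 1 is a limit, not a number.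

Compound 4 `O=C1COc2ccc(-c3cccc(NS(=O)(=O)c4ccc(F)cc4)c3)cc2N1c1ccc(Cl)cc1` differs from compound 2 in one place: 4-chlorophenyl in place of hydrogen on an amide-type nitrogen in a ring. Among the measured compounds shown here, the only measured step at this nitrogen is an at least 1.5-fold lower number from compound 1 to compound 3 (0.19 log units; that floor lies within the scatter). Its floor lies within the scatter, it swaps isopropyl for cyclohexyl, and the core of compound 1 differs from that of compound 2. For the measured compounds named here, no measured step places an aromatic ring here, so no clear step beyond the scatter is expected in either direction. The expected change is a 1.3-fold lower number from compound 2 to compound 4 (0.10 log units; within the scatter). The estimate for compound 4 is 16000 nM, with an expected range from 3000 nM to 45000 nM.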

Compound 4, half-maximal inhibitory concentration: 32500 nM
For compound 4 the middle estimate is 2.0-fold (0.31 log units) below the measured one; low and high end bracket the measured number.
By their numbers in this assay, from the lowest: compounds 2, 3 and 4 (each within the scatter of the next). At a limit, above all of these: compound 1.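

In this assay, 4-chlorophenyl in place of hydrogen on the amide-type nitrogen gives a 1.6-fold higher number from compound 2 to compound 4 (0.21 log units; within the scatter). Among these compounds, this is the first direct reading of an aromatic ring at this position, and it shows that the nitrogen can carry this group without a step beyond the scatter. Little room remains for any upward change, since compound 1 already stands at a limit, which is not a number: the limit of > 40000 nM in this assay, at which 1 of the 4 values shown sits.

As far as these compounds go, whether an amine, a carboxylic acid or a longer chain on this nitrogen would give a step beyond the scatter stays open. So does whether 4-chlorophenyl would read the same on the core of compound 1.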